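Piperazine substituent changes on an aminothiazolopyrimidine core

The source may report more compounds than this note shows. Statements on the series, on what has been measured and on what is new or still open speak of the compounds shown alone.

Measured compounds:
- compound 1: `CC(C)(Oc1ccc(Cl)cc1)C(=O)N1CCN(c2nc(N)nc3sc(-c4ccc(F)cc4)nc23)CC1`; in a functional assay on cells (Lymphocyte, Homo sapiens) (a lower number here means a stronger inhibitor, a higher number a weaker inhibitor), compound 1 gives > 10000 nM, a limit of the assay.
- compound 2: `CCCCCN1CCN(c2nc(N)nc3sc(-c4ccc(F)cc4)nc23)CC1`; compound 2 gives > 10000 nM, again a limit.
- compound 3: `Cc1cccc(N2CCN(c3nc(N)nc4sc(-c5ccc(F)cc5)nc34)CC2)c1`; compound 3 gives > 10000 nM, also a limit.

All three measured compounds sit at the limit of > 10000 nM in this assay, at which 3 of the 3 values shown sit, so no number is known for any of them, and compound 3 stands exactly where compounds 1 and 2 stand, at the limit. Among the measured compounds shown here, the one step among them, a step that the two limits leave unreadable from compound 2 to compound 3, cannot be sized, as both ends are limits.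

The next compound, compound 4, is `Nc1nc(N2CCN(C(=O)COc3ccccc3)CC2)c2nc(-c3ccc(F)cc3)sc2n1`. It differs from compound 3 by (phenoxymethyl)carbonyl in place of 3-methylphenyl on an amine nitrogen in a ring. For the measured compounds named here, no measured step bears directly on this change. What the data offer is that compound 1, whose structure also joins a carbonyl to a phenoxy-bearing unit, gives only a limit in this assay, and compound 3 itself gives only a limit. Nothing among the shown values points to a gain beyond the scatter from this substitution. Compound 4 is therefore expected to remain near the limit, with the estimated step that the limit leaves unreadable from compound 3 to compound 4 being no real change. The estimate for compound 4 is 12000 nM, within 4000 nM to 40000 nM.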

Compound 4, half-maximal inhibitory concentration: 90 nM
Estimate against measurement, compound 4: 130-fold (2.12 log units) above, and the stated range ends above it.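

Among the compounds shown here, compound 4 is the first compound here with a readable number, and it shows that the group on the amine nitrogen in a ring can decide activity in this assay: (phenoxymethyl)carbonyl gives an at least 110-fold lower number from compound 3 to compound 4 (2.04 log units; beyond the scatter) in place of 3-methylphenyl, and an at least 110-fold lower number from compound 2 to compound 4 (2.04 log units; beyond the scatter) in place of pentyl. A carbonyl on that nitrogen does not suffice on its own, for compound 1 carries one too, and changing only the group on the carbonyl carbon gives an at least 110-fold lower number from compound 1 to compound 4 (2.04 log units; beyond the scatter). Each of these sizes is only a lower bound, because compound 1, compound 2 and compound 3 all stand at a limit: the limit of > 10000 nM in this assay, at which 3 of the 4 values shown sit.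

The compounds shown do not separate the chlorine of compound 1 from its two methyl groups, which differ from compound 4 together, so a phenoxy ring bearing chlorine alone would be needed to tell them apart. As far as these compounds go, it also stays open how much of the activity of compound 4 rests on the ether oxygen and on the length of the link, which a benzoyl group or a longer chain between the carbonyl and the oxygen would test.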